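A few compounds are considered here, and "the series" means these few. Any claim that something is new, unique, unknown or untested is made for them only; others in the source may bear on it.

Measured so far in a functional assay (cardiac atrium) for agonist activity, with Cavia porcellus as the target; a lower number here means that less compound is needed, a higher number that more compound is needed for the effect: compound 1 `CCO/C(O)=C1\C(C)=NC(C)=C([N+](=O)[O-])C1c1ccncc1` gives 6460 nM; compound 2 `CC1=NC(C)=C([N+](=O)[O-])C(c2cccnc2)/C1=C(\O)OC(C)C` gives 28500 nM; compound 3 `CC1=NC(C)=C([N+](=O)[O-])C(c2cccnc2)/C1=C(\O)OC1CCCC1` gives 3280 nM.

Compound 3 has the lowest number of the three. Its gap to compound 1 lies within the scatter, so no order between those two can be claimed; its gap to compound 2 lies beyond the scatter.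

Compound 4 `CCO/C(O)=C1\C(C)=NC(C)=C([N+](=O)[O-])C1c1cccnc1` differs from compound 3 in one place: ethyl in place of cyclopentyl on an oxygen on an unsaturated carbon. Within the data shown here, the only measured step that bears on this position is an 8.7-fold lower number from compound 2 to compound 3 (0.94 log units; beyond the scatter), where a larger ring replaced a branched group on the same oxygen and the number fell. Compound 4 carries the smaller ethyl in place of cyclopentyl, so the expectation is a step in the opposite direction. Whether ethyl behaves like isopropyl is not known from these compounds; compound 1, which also carries ethyl but differs elsewhere, gives a number between those of compound 3 and compound 2.

For compound 4 the expected step is a 4.6-fold higher number from compound 3 to compound 4 (0.66 log units; beyond the scatter), a higher number in this assay. Compound 4 is estimated at 15000 nM, with a range from 4000 nM to 50000 nM.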

Compound 4, half-maximal effective concentration: 8840 nM
Beside the measured number, compound 4's estimate is 1.7-fold (0.23 log units) above it; measured number inside the range.
By their numbers in this assay, from the lowest: compounds 3, 1 and 4 (each within the scatter of the next, the first and the last beyond it); then compound 2.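

With pyridin-3-yl held fixed, the oxygen on the unsaturated carbon now has three groups that separate beyond the scatter: a 2.7-fold higher number from compound 3 to compound 4 (0.43 log units; beyond the scatter), and a 3.2-fold lower number from compound 2 to compound 4 (0.51 log units; beyond the scatter). The number therefore does not rise steadily as the group shrinks from cyclopentyl to ethyl, since compound 2, with isopropyl, goes against such a trend by giving the highest number of the three. With ethyl on this oxygen, the ring change gives a 1.4-fold higher number from compound 1 to compound 4 (0.14 log units; within the scatter), so pyridin-3-yl and pyridin-4-yl cannot be ordered here.

Nothing available explains why isopropyl gives the highest number of the three. Still open, on these data alone, are how methyl, a longer chain such as butyl or a cyclohexyl ring on this oxygen would compare, and whether pyridin-4-yl would give the same order of these groups.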